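Oxindole-thiazolone series: chloro for methoxy at compound 4

The source may hold more compounds than are shown below. What is called first, only, known or untested is meant among the compounds shown, and "the series" means these compounds.

Measured compounds in a functional assay on cells (Cancer cell lines, Homo sapiens) for cytotoxicity, read by sulforhodamine B assay, with a stated time of 48 h; a lower number here means a stronger inhibitor of growth, a higher number a weaker inhibitor of growth:
compound 1 `COc1ccc(C2=NN(C3=NC(=O)/C(=C4\C(=O)Nc5ccccc54)S3)C(c3ccc(OC)cc3)C2)cc1` gives 100000 nM
compound 2 `COc1ccc(C2CC(c3ccc4ccccc4c3)=NN2C2=NC(=O)/C(=C3\C(=O)Nc4ccccc43)S2)cc1` gives 13600 nM
compound 3 `COc1ccc(C2CC(c3ccc4ccccc4c3)=NN2C2=NC(=O)/C(=C3\C(=O)Nc4ccc(Br)cc43)S2)cc1` gives 330 nM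

Compound 2 stands second highest of the three numbers; its nearest neighbour is compound 1 with a 7.4-fold lower number from compound 1 to compound 2 (0.87 log units; beyond the scatter), its furthest compound 3 with a 41-fold lower number from compound 2 to compound 3 (1.62 log units; beyond the scatter).

Compound 4 `O=C1N=C(N2N=C(c3ccc4ccccc4c3)CC2c2ccc(Cl)cc2)S/C1=C1/C(=O)Nc2ccccc21` is not yet measured. It differs from compound 2 by chloro in place of methoxy on an aromatic carbon. Neither measured step touches this position: the step from compound 1 to compound 2 alters the other aryl group, and the step from compound 2 to compound 3 alters the fused ring. Going by the values given here, no measured step therefore bears on the change, and nothing beyond the scatter is expected in this assay, in either direction. Compound 4 is estimated at 10000 nM, within 3000 nM to 40000 nM, meaning an expected 1.4-fold lower number from compound 2 to compound 4 (0.13 log units; within the scatter).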

Compound 4, concentration for total growth inhibition: 42100 nM
Compound 4: middle estimate off by 4.2-fold (0.62 log units), on the low side; measured number above the stated range.
By their numbers in this assay, from the lowest: compound 3; then compound 2; then compound 4; then compound 1.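

In this assay, going by these compounds alone, chloro in place of methoxy gives a 3.1-fold higher number from compound 2 to compound 4 (0.49 log units; beyond the scatter) with naphthalen-2-yl held constant, so this aromatic carbon is a position that responds to substitution, which the earlier steps could not show. Of these two groups, methoxy goes with the stronger growth inhibition. No measurement shown accounts for this shift.

On these data alone, whether the loss follows from chloro itself or from the removal of methoxy stays open, as does the effect of a hydroxy or dimethylamino group here. Also open, as far as these compounds go, is whether the gain from bromo on the fused ring carries over to the 4-chlorophenyl compound.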